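Pyridinyl to Phenyl Swap on the Shared Core

The source may hold more compounds than are shown below. What is called first, only, known or untested is meant among the compounds shown, and "the series" means these compounds.

Compound 1 `Cc1ccc(NC(=O)CN2CCN(c3nnc(Cc4ccncc4)c4ccccc34)CC2)c(C)c1`: 1930 nM
Compound 2 `O=C(CN1CCN(c2nnc(Cc3ccncc3)c3ccccc23)CC1)Nc1cc(C(F)(F)F)ccc1Cl`: 4810 nM

In a functional assay on HT-29 cells (Homo sapiens) for cytotoxicity, read by MTT assay, with a stated time of 72 h (on this read-out lower numbers stand for stronger inhibition and higher numbers for weaker inhibition), compound 1 gives 1930 nM, the lowest of the two numbers shown. Compound 2 gives 4810 nM. Going by the values given here, the only measured step, a 2.5-fold higher number from compound 1 to compound 2 (0.40 log units; beyond the scatter), concerns the aryl on the amide-type nitrogen, with a modest rise.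

Compound 3 `Cc1ccc(NC(=O)CN2CCN(c3nnc(Cc4ccccc4)c4ccccc34)CC2)c(C)c1` differs from compound 1 elsewhere: phenyl in place of pyridin-4-yl on a saturated chain carbon bound to an aromatic carbon. Cut one bond further out, the change reads (pyridin-4-yl)methyl to benzyl. Among the compounds with values here, no measured pair touches this part of the shared core, so the step from compound 1 to compound 2 offers no direct guide, and the data give no direction for this change. Compound 3 is therefore expected to sit close to compound 1, a step of a 1.1-fold higher number from compound 1 to compound 3 (0.06 log units; within the scatter) that need not exceed the scatter. The estimate for compound 3 in this assay is 2200 nM, with a range from 800 nM to 6000 nM.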

Compound 3, half-maximal inhibitory concentration: "not active" (no number reported)
Compound 3: no number reported, and the estimate cannot be compared.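

In this assay, going by these compounds alone, compound 3 is reported as "not active" with no number, so no step from compound 1 to compound 3 can be read. No available evidence bears on this result. The compounds shown leave open how large the change from pyridin-4-yl to phenyl is on this read-out.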